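The source may report more compounds than this note shows. Statements on the series, on what has been measured and on what is new or still open speak of the compounds shown alone.

Measured so far in an assay for inhibition of alcohol dehydrogenase (Equus caballus), read by spectrophotometry, in the presence of a further agent that is not named here; on this read-out lower numbers stand for tighter binding and higher numbers for weaker binding:
compound 1, `OCCCc1cn[nH]c1`: 560 nM
compound 2, `ClCCCc1cc[nH]n1`: 40000 nM
compound 3, `ClCCc1cc[nH]n1`: 200000 nM

Compound 1 gives the lowest number of the three in this assay; its gap to compound 2 and its larger gap to compound 3 both lie beyond the scatter, so compound 1 is the tightest binder of the measured set. Within the data shown here, the only step between measured compounds is a 5.0-fold higher number from compound 2 to compound 3 (0.70 log units; beyond the scatter), which concerns chloro in place of chloromethyl on the core of compound 2 and does not touch a hydroxy group.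

Compound 4, `ClCCCc1cn[nH]c1`, is not yet measured. It differs from compound 1 by chloro in place of hydroxy on a saturated chain carbon, three bonds along the chain from an aromatic carbon. Among the measured compounds shown here, no measured step covers this exchange directly. What the numbers show is that compound 2, carrying chloro on a saturated chain carbon, three bonds along the chain from an aromatic carbon, sits far higher than compound 1, which carries hydroxy in that place; since the two cores also differ, the comparison is indirect, and the step from compound 2 to compound 3 gives no guidance on direction here. On this footing the exchange is expected to weaken binding, with wide uncertainty.

Compound 4 is therefore expected at 15000 nM in this assay, within 2000 nM to 150000 nM, corresponding to an expected step of a 27-fold higher number from compound 1 to compound 4 (1.43 log units; beyond the scatter).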

Compound 4, dissociation constant: 20 nM
Compound 4: middle estimate off by 750-fold (2.88 log units), on the high side, and the stated range ends above it.
By their numbers in this assay, from the lowest: compound 4; then compound 1; then compound 2; then compound 3.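

In this assay, putting chloro where the hydroxy group stood tightens binding on the shared core, as a large step: a 28-fold lower number from compound 1 to compound 4 (1.45 log units; beyond the scatter). The chloro group does not by itself go with a high number: compound 2, with a chloro-ended chain on a different core, gives 40000 nM, whereas compound 4 gives 20 nM, so the hydroxy group, with its hydrogen-bond donor and acceptor, is not required at this place for tight binding on this core. Nothing in hand explains why the exchange tightens binding.

Among these compounds, whether the gain is particular to chloro or extends to other groups at this place, such as bromo, methyl or an amine, remains open, and so does chain length on this core, since the only shortening step, a 5.0-fold higher number from compound 2 to compound 3 (0.70 log units; beyond the scatter), lies on the other core and a 2-chloroethyl chain on the shared core would test it. Also open, going by these compounds, is whether the order of compound 1 and compound 4 holds without the further agent present in this assay.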